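Replacing the quinolinyl amide of compound 3 with a bromophenyl

The source may report more compounds than this note shows. Statements on the series, on what has been measured and on what is new or still open speak of the compounds shown alone.

Measured so far:
compound 1, `CCN1CCN(c2cc(C)c3cc(NC(=O)c4cccc(Cl)c4)ccc3n2)CC1`, 17800 nM;
compound 2, `CCc1ccccc1C(=O)Nc1ccc2nc(N3CCN(CC)CC3)cc(C)c2c1`, 23900 nM;
compound 3, `CCN1CCN(c2cc(C)c3cc(NC(=O)c4ccc5ccccc5n4)ccc3n2)CC1`, 3760 nM.

In a functional assay on SK-BR-3 cells (Homo sapiens) for antiproliferative activity, read by MTT assay, with a stated time of 72 h (on this read-out higher numbers stand for weaker inhibition and lower numbers for stronger inhibition), compound 3 stands lowest of the three, with the nearest value being that of compound 1 (a 4.7-fold lower number from compound 1 to compound 3 (0.68 log units; beyond the scatter)) and the furthest that of compound 2 (a 6.4-fold lower number from compound 2 to compound 3 (0.80 log units; beyond the scatter)). The unmeasured compound 4, `CCN1CCN(c2cc(C)c3cc(NC(=O)c4cccc(Br)c4)ccc3n2)CC1`, differs from compound 3 by 3-bromophenyl in place of quinolin-2-yl on a carbonyl carbon. For the measured compounds named here, the step that bears on this change is the one from compound 1 to compound 3, which replaced a chlorophenyl with the quinolinyl group and lowered the number; compound 4 undoes that change with a closely related halophenyl. A step of similar size in the opposite direction is therefore expected, a 4.3-fold higher number from compound 3 to compound 4 (0.63 log units; beyond the scatter). For compound 4 the estimated value in this assay is 16000 nM, with a range from 6000 nM to 40000 nM.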

Compound 4, half-maximal inhibitory concentration: 13300 nM
The estimate for compound 4 lay 1.2-fold (0.08 log units) above the measured number; low and high end bracket the measured number.
By their numbers in this assay, from the lowest: compound 3; then compounds 4, 1 and 2 (each within the scatter of the next).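

In this assay the quinolin-2-yl group now stands apart from a second halophenyl on the carbonyl carbon, with a 3.5-fold higher number from compound 3 to compound 4 (0.55 log units; beyond the scatter) beyond the scatter. Bromo in place of chloro on the aromatic carbon gives a 1.3-fold lower number from compound 1 to compound 4 (0.13 log units; within the scatter) within the scatter, and 3-bromophenyl in place of 2-ethylphenyl gives a 1.8-fold lower number from compound 2 to compound 4 (0.25 log units; within the scatter) within it as well, so compounds 1, 2 and 4 form one group and only compound 3 separates from it. From the compounds shown here alone, what a naphthalen-2-yl or a pyridin-2-yl group would give at this carbonyl carbon stays open, and with it whether the second ring or the ring nitrogen of quinolin-2-yl carries the difference. Nothing measured here explains that difference.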